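This account rests on a few compounds, and the source may have more. Where it says the series, first, only, none or still open, it means among the compounds named here.

In a functional assay on the whole organism (stomach) with Rattus norvegicus as the target (a higher number here means that more compound is needed for the effect, a lower number that less compound is needed), compound 1, `CC/N=C(/NC#N)NCCCCn1nc(-c2ccccc2)ccc1=O`, gives 92 mg/kg. Compound 2, `C/N=C(/NC#N)NCCCCCn1nc(-c2ccccc2)c(C)cc1=O`, stops at the limit of the assay, > 100 mg/kg. Compound 3, `CC/N=C(/NC#N)NCCCCn1nc(-c2ccccc2)c(C)cc1=O`, likewise stops at the limit of the assay, > 100 mg/kg, so its standing in this assay is known only as a floor. Where compound 3 sits is described by the limit of > 100 mg/kg in this assay, at which 2 of the 3 values shown sit. For that reason the step of an at least 1.0-fold higher number from compound 1 to compound 3 (0.03 log units; that floor lies within the scatter) can be given only as a floor, and the step that the two limits leave unreadable from compound 2 to compound 3 remains without a readable size.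

Compound 4, `C/N=C(/NC#N)NCCCCn1nc(-c2ccccc2)c(C)cc1=O`, differs from compound 3 by hydrogen in place of methyl on a saturated chain carbon bound to a double-bonded nitrogen. Of the measured steps, a step that the two limits leave unreadable from compound 2 to compound 3 is the one that touches the same group on the double-bonded nitrogen, and it is unreadable; the step from compound 1 to compound 3 changes a different place and is also only a floor. Neither gives a usable size, so no step beyond the scatter is expected in this assay, which is what the estimated step that the limit leaves unreadable from compound 3 to compound 4 expresses. Compound 4 is accordingly expected to give about 150 mg/kg, within 70 mg/kg to 400 mg/kg, with a fair chance that this assay reports only its limit again.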

Compound 4, dose for half-maximal effect: > 100 mg/kg
Compound 4 gave a limit, no number; the forecaster's own chance of this, stated with the estimate: 65%; the middle value is on the limit's open side.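

Compound 4 also stops at a limit in this assay, > 100 mg/kg. No step from compound 2 or compound 3 to compound 4 can be read, and the data now stand thus: the limit of > 100 mg/kg in this assay, at which 3 of the 4 values shown sit.

The compounds shown leave open how hydrogen in place of methyl on a saturated chain carbon bound to a double-bonded nitrogen acts in this assay.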